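The compounds below may be only part of what the source reports. "The series", "measured", "known", "first", "only" and "open" are said of these compounds alone.

Three compounds sharing one core have numbers in a functional assay on HepG2 cells (Homo sapiens) for cytotoxicity, read by MTT assay, with a stated time of 48 h (on this read-out higher numbers stand for weaker inhibition and lower numbers for stronger inhibition), so far. There compound 1 (`CCN(CC)CC(=O)N1N=C(C)CC1c1ccccc1O`) gives 51600 nM as its value, compound 2 (`CC1=NN(C(=O)CN2CCCC2)C(c2ccccc2O)C1`) gives 5540 nM as its value and compound 3 (`CC1=NN(C(=O)CN2CCC(c3ccccc3)CC2)C(c2ccccc2O)C1`) gives 23300 nM as its value, which places compound 3 between the other two. Still unmeasured is compound 4 (`CC1=NN(C(=O)CN2CCC(Cl)CC2)C(c2ccccc2O)C1`), which differs from compound 3 by having chloro in place of phenyl on a saturated ring carbon. Among the compounds with values here, the only measured step between compounds differing in one place is modest (a 9.3-fold lower number from compound 1 to compound 2 (0.97 log units; beyond the scatter)), and it has pyrrolidin-1-yl in place of diethylamino, a change in another place. Within the data shown here, no measured step replaces phenyl with chloro, so this step bears on compound 4 only indirectly, as a guide to how far a single change can move the numbers in this assay within this small set. A large step is therefore not expected, only a small one towards a lower number that stays within the scatter. The estimated step is a 1.7-fold lower number from compound 3 to compound 4 (0.22 log units; within the scatter) and remains uncertain. The expected value for compound 4 is 14000 nM with an estimated range from 5000 nM to 40000 nM in this estimate.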

Compound 4, half-maximal inhibitory concentration: 42100 nM
Compound 4: the middle estimate sits 3.0-fold (0.48 log units) below what was measured, outside the stated range (above it).
By their numbers in this assay, from the lowest: compound 2; then compounds 3, 4 and 1 (each within the scatter of the next, the first and the last beyond it).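

In this assay, within the data shown here, the saturated ring carbon three ring bonds from the ring nitrogen now carries a second group, and chloro in place of phenyl gives (a 1.8-fold higher number from compound 3 to compound 4 (0.26 log units; within the scatter)), so these two groups cannot be told apart at this place in this read-out, something the earlier compounds, with phenyl alone there, could not show. The 4-chloropiperidin-1-yl group also adds to the comparison of amines on the saturated chain carbon: in place of diethylamino it gives (a 1.2-fold lower number from compound 1 to compound 4 (0.09 log units; within the scatter)), which leaves compound 4 and compound 1 inseparable, while in place of pyrrolidin-1-yl it gives (a 7.6-fold higher number from compound 2 to compound 4 (0.88 log units; beyond the scatter)), so compound 2 stands clear of compound 4. No measured information accompanies these values that could explain them.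

The compounds shown leave open whether plain piperidin-1-yl, with only hydrogen on that ring carbon, would read like compound 3 and compound 4, and whether a hydroxyl or a methyl group there would do the same. They also leave open whether morpholin-4-yl or azetidin-1-yl on the chain carbon would stand with compound 2 or with compound 4.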